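Swapping a Fluorophenyl Arm for a Hydroxypentyl Chain

The source may report more compounds than this note shows. Statements on the series, on what has been measured and on what is new or still open speak of the compounds shown alone.

Of the compounds shown here, two that share one core have so far been measured in an ADME assay on HeLa cells (Homo sapiens) for cytotoxicity, read by sulforhodamine B assay, with a stated time of 48 h, tested at 10 uM; a higher number here means more inhibition at the concentration tested (going by the name of the read-out), a lower number less inhibition. Compound 1 `COc1nc2ccc(Br)cc2cc1C(c1ccccc1)n1cc(-c2ccc(OC(F)(F)F)cc2)nn1` carries a 4-(trifluoromethoxy)phenyl group and gives -2.24%. Compound 2 `COc1nc2ccc(Br)cc2cc1C(c1ccccc1)n1cc(-c2cccc(F)c2)nn1` carries 3-fluorophenyl in its place and gives 9.04%. For the measured compounds named here, the one measured step, a number 11.3 percentage points higher from compound 1 to compound 2 (beyond the scatter), is the only comparison available. Compound 2 therefore holds the higher of the two numbers, with compound 1 as its nearest neighbour a step below it beyond the scatter, though both numbers lie close to zero.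

Compound 3 `COc1nc2ccc(Br)cc2cc1C(c1ccccc1)n1cc(CCCCCO)nn1` has not yet been measured. Its change from compound 2 is 5-hydroxypentyl in place of 3-fluorophenyl on an aromatic carbon, so the 3-fluorophenyl group leaves and 5-hydroxypentyl enters on an aromatic carbon. Going by the values given here, no measured step exchanges an aromatic group for a chain; the only step seen exchanged one aromatic group for another and moved the number modestly. With both measured numbers near zero, the step is expected to be a number 5 percentage points lower from compound 2 to compound 3 (within the scatter), within the scatter. Compound 3 is estimated at 4% in this assay, with a range from -10% to 18%.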

Compound 3, a percentage reported as inhibition, at one concentration (the size of the read-out at that concentration, not a potency): 1.08%
Compound 3: middle estimate off by 2.9 percentage points, on the high side, and the stated range covers the measured number.
By their numbers in this assay, from the lowest: compounds 1, 3 and 2 (each within the scatter of the next, the first and the last beyond it).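

For the compounds shown here, with 5-hydroxypentyl, the position on the five-membered aromatic ring with 3 nitrogen carries a group with no ring for the first time, and in this assay the exchange for 3-fluorophenyl is a number 8 percentage points lower from compound 2 to compound 3 (within the scatter) and so cannot be read as a real change. The exchange for 4-(trifluoromethoxy)phenyl is a number 3.3 percentage points higher from compound 1 to compound 3 (within the scatter) and is likewise unreadable, so compound 3 cannot be separated from either aryl-bearing compound, even though those two stand apart from each other and the aromatic ring at this position proves not to be required to keep the number in this same range close to zero. No measurement is at hand that would explain these numbers or say what lies behind the small gap between the two aryl-bearing compounds.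

The compounds shown leave open whether the length of the chain or its terminal hydroxyl has any bearing on the read-out, which a plain pentyl chain, a shorter hydroxypropyl chain or a longer chain would test. They also leave open whether a chain ending in an amine or a carboxylic acid, or any other group at this position, would lift the number clearly away from zero in this assay at all.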